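Swapping the acylated amine of compound 3 for a sulfonamide

The source may hold more compounds than are shown below. What is called first, only, known or untested is meant among the compounds shown, and "the series" means these compounds.

Three members of the series have readings in a functional assay on PC-3 cells (Homo sapiens) for inhibition, read by CellTiter-Glo, with a stated time of 72 h; on this read-out higher numbers stand for lower toxicity in this test and lower numbers for higher toxicity in this test. Compound 1 `CC1=C(CC(=O)N(C)CCN(C)C)c2cc(F)ccc2/C1=C\c1nc2ccccc2s1` gives 5880 nM and compound 2 `CC1=C(CC(=O)NCCN2CCCC2)c2cc(F)ccc2/C1=C\c1ccncc1` gives 10200 nM, two values within the usual scatter of each other.

Compound 3 `CC1=C(CC(=O)N(C)CCN(C)C(=O)[C@@H](N)C(C)C)c2cc(F)ccc2/C1=C\c1ccc([S+](C)[O-])cc1` reads > 50000 nM, which is a limit of the assay and not a number. It therefore stands at the limit, and its true position is not known.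

Compound 4 `CC1=C(CC(=O)N(C)CCN(C)S(=O)(=O)c2ccc(C)cc2)c2cc(F)ccc2/C1=C\c1ccc([S+](C)[O-])cc1` keeps all of compound 3 except one group: (4-methylphenyl)sulfonyl in place of (1-amino-2-methylpropyl)carbonyl on an amine nitrogen. Among the compounds with values here, no measured pair isolates this change, so the size of the step in this assay cannot be read from the data.

Compound 1 at 5880 nM shows that the series can give a number well inside the range of the assay, though it differs from compound 4 in more than one place. A modest expected shift towards lower numbers is therefore the working assumption, with a reading at the limit remaining quite possible. The step of an at least 1.4-fold lower number from compound 3 to compound 4 (0.15 log units; that floor lies within the scatter) is expected to be small.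

Compound 4 is estimated at 35000 nM, with an expected range of 12000 nM to 70000 nM.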

Compound 4, half-maximal cytotoxic concentration: 11000 nM
Compound 4: middle estimate off by 3.2-fold (0.50 log units), on the high side, and the stated range ends above it.
By their numbers in this assay, from the lowest: compounds 1, 2 and 4 (each within the scatter of the next). At a limit, above all of these: compound 3.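

In this assay, (4-methylphenyl)sulfonyl in place of (1-amino-2-methylpropyl)carbonyl on an amine nitrogen gives an at least 4.5-fold lower number from compound 3 to compound 4 (0.65 log units; beyond the scatter), the only single change shown so far and one that lies beyond the scatter. The read-out at this position therefore responds to the group on this nitrogen, and compound 4 shows that a number can be obtained with the rest of compound 3 kept unchanged. For compound 3, > 50000 nM is a limit of the assay and not a number, so the step is only a floor on the true change, because its starting point is not a number: the limit of > 50000 nM in this assay, at which 1 of the 4 values shown sits.

The compounds shown leave open whether the step goes with the sulfonyl link, with the aromatic ring or with the loss of the amino group; a benzoyl or a methylsulfonyl group on the same amine nitrogen would separate these. They also leave open whether the same swap gives a step of similar size when the other parts of the molecule differ, as they do in compound 1 and compound 2.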